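The source may hold more compounds than are shown below. What is called first, only, known or untested is meant among the compounds shown, and "the series" means these compounds.

Among the compounds with values here, compound 1 `Cc1ccc(-c2cs/c(=N/NC(=O)CSc3nnnn3C)n2-c2ccccc2)cc1` gives 36.3 ug/mL in a functional assay on C6 cells (Rattus norvegicus) for cytotoxicity, read by MTT assay, with a stated time of 24 h (on this read-out lower numbers stand for stronger inhibition and higher numbers for weaker inhibition), the only number. For compound 2 `COc1ccc(-c2cs/c(=N/NC(=O)CSc3nnnn3C)n2-c2ccccc2)cc1` the outcome in this assay is "not determined" (no result reported), so compound 2 stands without a number of its own, and only the result for compound 1 offers a reference point. Compound 3 `COc1ccc(-c2cs/c(=N/NC(=O)CSc3ncccn3)n2-c2ccccc2)cc1` differs from compound 2 by pyrimidin-2-yl in place of 1-methyl-1H-tetrazol-5-yl on a sulfur. Within the data shown here, no step between measured compounds shows what this exchange does, so the shift is expected to stay within the scatter in either direction. Compound 3 is expected to reach about 35 ug/mL, within a range from 12 ug/mL to 100 ug/mL.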

Compound 3, half-maximal inhibitory concentration: 102 ug/mL
Beside the measured number, compound 3's estimate is 2.9-fold (0.46 log units) below it, and the stated range ends below it.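

Within the data shown here, compound 2 has no number in this assay, so no step from it to compound 3 can be read. From the compounds shown here alone, what pyrimidin-2-yl in place of 1-methyl-1H-tetrazol-5-yl does therefore stays open, and no evidence at hand bears on this result.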